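From propylsulfanyl to isopropylamino at a toxicity limit

A few compounds are considered here, and "the series" means these few. Any claim that something is new, unique, unknown or untested is made for them only; others in the source may bear on it.

Compound 1 `COCCOc1nc(N)nc2c1ncn2/C=C1/CC1(CO)CO` gives > 20000 nM
Compound 2 `CCCSc1nc(N)nc2c1ncn2/C=C1/CC1(CO)CO` gives > 20000 nM

In an ADME assay on BCBL1 cells (Homo sapiens) for cytotoxicity, with a stated time of 7 days (on this read-out higher numbers stand for lower toxicity in this test and lower numbers for higher toxicity in this test), compound 2 gives > 20000 nM as a limit, not a number. The change isopropylamino in place of propylsulfanyl on an aromatic carbon leads to compound 3 `CC(C)Nc1nc(N)nc2c1ncn2/C=C1/CC1(CO)CO` with isopropylamino in place of propylsulfanyl on an aromatic carbon. For the measured compounds named here, the only measured step that the two limits leave unreadable from compound 1 to compound 2 has no readable size, and both compounds share one limit (the limit of > 20000 nM in this assay, at which 2 of the 2 values shown sit). It offers no guide to direction, so no step beyond the scatter is expected in this assay here. The estimated step of a number no higher from compound 2 to compound 3 (the limit leaves the size open) is accordingly small. Compound 3 is estimated at 20000 nM with an expected range of 8000 nM to 40000 nM in this measurement.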

Compound 3, half-maximal cytotoxic concentration: > 20000 nM
Compound 3: only a limit was reported; the forecaster's own chance of this, stated with the estimate: 70%; the middle value sits exactly at the limit.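

Compound 3, like compound 1 and compound 2, is reported only as a limit and not as a number, so no step among these three compounds can be read: the limit of > 20000 nM in this assay, at which 3 of the 3 values shown sit.

On these data alone, whether the three compounds differ at all in this assay stays open.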